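Smaller amide substituent on a shared core

The source may hold more compounds than are shown below. What is called first, only, known or untested is meant among the compounds shown, and "the series" means these compounds.

compound 1 `CC(C)NC(=O)c1ccc(NCc2cncn2Cc2ccc(C#N)cc2)cc1-c1ccccc1`: > 10 uM
compound 2 `N#Cc1ccc(Cn2cncc2CNc2ccc(C(=O)Nc3cccc(C#N)c3)c(-c3ccccc3)c2)cc1`: > 10 uM

In a functional assay on NIH3T3 cells (Mus musculus) (on this read-out higher numbers stand for an effect only at larger amounts of compound and lower numbers for an effect already at smaller amounts), compound 1 reaches only the limit > 10 uM. Compound 2 likewise gives only the limit > 10 uM in this assay. The step that the two limits leave unreadable from compound 1 to compound 2 is therefore unreadable because of the limit of > 10 uM in this assay, at which 2 of the 2 values shown sit. Compound 2 thus stands at the limit of this assay, with no number of its own to place it within the measured range.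

Compound 3 `N#CCNC(=O)c1ccc(NCc2cncn2Cc2ccc(C#N)cc2)cc1-c1ccccc1` differs from compound 2 by cyanomethyl in place of 3-cyanophenyl on an amide-type nitrogen. Going by the values given here, the only measured step at this amide-type nitrogen, a step that the two limits leave unreadable from compound 1 to compound 2, gives no size at all, so no direction beyond the scatter can be expected for this change. The step that the limit leaves unreadable from compound 2 to compound 3 is therefore expected to stay within the scatter. Compound 3 is estimated at 20 uM, with a range from 8 uM to 60 uM, and is expected most likely to be reported again only as a limit.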

Compound 3, concentration for half-maximal effect: > 10 uM
Compound 3 was reported as a limit; the forecaster's own chance of this, stated with the estimate: 85%; the middle value lies beyond the limit too.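

In this assay compound 3 gives only a limit, > 10 uM. Going by these compounds alone, no step among compound 1, compound 2 and compound 3 can be read, because all their values sit at one limit: the limit of > 10 uM in this assay, at which 3 of the 3 values shown sit. The compounds shown leave open how far any of these amide substituents changes the concentration for half-maximal effect.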